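Furanyl in place of thienyl on the chalcone chain

The source may hold more compounds than are shown below. What is called first, only, known or untested is meant among the compounds shown, and "the series" means these compounds.

Measured compounds:
Compound 1 `COc1ccc(C(=O)/C=C/c2ccccc2)c2c1C=CC(C)(C)O2`; in a functional assay on K562 cells (Homo sapiens) for antiproliferative activity, read by MTT assay, with a stated time of 24 h (a higher number here means a weaker inhibitor, a lower number a stronger inhibitor), compound 1 gives > 10000 nM, which is a limit of the assay.
Compound 2 `COc1ccc(C(=O)/C=C/c2ccsc2)c2c1C=CC(C)(C)O2`; in this assay compound 2 gives > 10000 nM, which is again a limit of the assay.

Compound 2 therefore stands only at a limit and has no number of its own. Going by the values given here, the one measured step, a step that the two limits leave unreadable from compound 1 to compound 2, is itself unreadable, since the limit of > 10000 nM in this assay, at which 2 of the 2 values shown sit, holds both ends of it. The change now followed is furan-2-yl in place of thiophen-3-yl on a double-bonded chain carbon bound to a double-bonded chain carbon, giving compound 3 `COc1ccc(C(=O)/C=C/c2ccco2)c2c1C=CC(C)(C)O2`. Among the compounds with values here, no measured step speaks to this exchange, and the only evidence, (the limit of > 10000 nM in this assay, at which 2 of the 2 values shown sit), shows that neither neighbour of compound 3 reached a number. Compound 3 is thus expected to sit at the same limit, with a step that the limit leaves unreadable from compound 2 to compound 3 estimated as no step beyond the scatter. The estimate for compound 3 is 15000 nM, with a range from 5000 nM to 50000 nM.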

Compound 3, half-maximal inhibitory concentration: > 10000 nM
Compound 3 ended at the assay's limit; the forecaster's own chance of this, stated with the estimate: 80%; the middle value is on the limit's open side.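

Compound 3 gives > 10000 nM in this assay, which is a limit of the assay. Its steps from compound 1 and from compound 2 therefore cannot be read: the limit of > 10000 nM in this assay, at which 3 of the 3 values shown sit. The compounds shown leave open how phenyl, thiophen-3-yl and furan-2-yl rank against one another on this chain.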